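The source may hold more compounds than are shown below. What is called first, only, known or untested is meant among the compounds shown, and "the series" means these compounds.

Measured compounds:
- compound 1 `O=C(Nc1cccc(-n2cc(-c3ccncc3)c(-c3ccc(Cl)c(O)c3)n2)c1)Nc1ccc(Cl)c(Cl)c1` gives 8330 nM
- compound 2 `COc1cc(-c2nn(-c3cccc(NC(=O)c4cccc(C(F)(F)F)c4)c3)cc2-c2ccncc2)ccc1Cl` gives 9960 nM
- compound 3 `O=C(Nc1cccc(-n2cc(-c3ccncc3)c(-c3ccc(Cl)c(O)c3)n2)c1)Nc1cc(C(F)(F)F)cc(C(F)(F)F)c1` gives 1660 nM

These three compounds were tested in a functional assay on MDA-MB-231 cells (Homo sapiens) for inhibition, read by sulforhodamine B assay, with a stated time of 48 h; on this read-out higher numbers stand for weaker inhibition of growth and lower numbers for stronger inhibition of growth. Compound 2 stands at the highest of the three numbers. Compound 1 sits within the scatter of compound 2, so the two cannot be told apart on this read-out. Compound 3 sits well beyond the scatter, its number being markedly lower than that of compound 2, though no single-point comparison between them is available.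

The next compound, compound 4 `COc1cc(-c2nn(-c3cccc(NC(=O)c4ccccc4)c3)cc2-c2ccncc2)ccc1Cl`, has not yet been tested in this assay. It differs from compound 2 in one place: hydrogen in place of trifluoromethyl on an aromatic carbon. No such step has been measured among the compounds shown, so the size and direction of the change can only be expected, not read off. The author expects compound 4 to come out close to compound 2, with at most a small shift toward weaker growth inhibition, a step of a 1.5-fold higher number from compound 2 to compound 4 (0.18 log units; within the scatter) that lies within the usual scatter. Compound 4 is therefore estimated at 15000 nM, with a likely range from 6000 nM to 40000 nM.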

Compound 4, concentration for total growth inhibition: 13700 nM
Compound 4: middle estimate off by 1.1-fold (0.04 log units), on the high side; measured number inside the range.
By their numbers in this assay, from the lowest: compound 3; then compounds 1, 2 and 4 (each within the scatter of the next).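

In this assay, for the compounds shown here, the step of a 1.4-fold higher number from compound 2 to compound 4 (0.14 log units; within the scatter) is the first single change that can be read, and it lies within the scatter. On this core, 3-(trifluoromethyl)phenyl and phenyl on the carbonyl therefore cannot be told apart, so the read-out gives no sign that trifluoromethyl at this position matters for growth inhibition. Nothing given here accounts for this outcome.

Going by these compounds alone, it remains open whether an amine or a carboxylic acid at the same ring position would also leave the number unchanged, since hydrogen and trifluoromethyl are the only two groups compared there. As far as these compounds go, it also remains open whether the same exchange would behave alike in the core of compound 3, whose steps to the other compounds cannot be read as single changes.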